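Three Chromene Carboxamides and a Piperidine Analogue

The source may hold more compounds than are shown below. What is called first, only, known or untested is meant among the compounds shown, and "the series" means these compounds.

The measured compounds in a functional assay for inhibition of nuclear factor NF-kappa-B complex (Homo sapiens); on this read-out lower numbers stand for stronger inhibition and higher numbers for weaker inhibition:
compound 1 `COc1ccc2c(c1)OC(c1cc(OC)c(OC)c(OC)c1)C(C(=O)Nc1ccccc1)=C2` gives 17500 nM
compound 2 `CCCCNC(=O)C1=Cc2ccc(OC)cc2OC1c1cc(OC)c(OC)c(OC)c1` gives 25500 nM
compound 3 `COc1ccc2c(c1)OC(c1cc(OC)c(OC)c(OC)c1)C(C(=O)OC(C)C)=C2` gives 11800 nM

Compound 2 has the highest number of the three, yet only compound 3 sits beyond the scatter from it; compound 1 is within it. The unmeasured compound 4 `COc1ccc2c(c1)OC(c1cc(OC)c(OC)c(OC)c1)C(C(=O)N1CCCCC1)=C2` differs from compound 2 by piperidin-1-yl in place of butylamino on a carbonyl carbon. For the measured compounds named here, two measured steps bear on it: a 1.5-fold higher number from compound 1 to compound 2 (0.16 log units; within the scatter), and a 2.2-fold lower number from compound 2 to compound 3 (0.33 log units; beyond the scatter). Both changes at the same carbonyl moved the numbers little, so a similar change is expected to do the same. Compound 4 is therefore estimated at 18000 nM, between 8000 nM and 40000 nM, which means a step of a 1.4-fold lower number from compound 2 to compound 4 (0.15 log units; within the scatter) is expected, most likely within the scatter.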

Compound 4, half-maximal inhibitory concentration: > 50000 nM
Compound 4 gave a limit, no number; the forecaster's own chance of this, stated with the estimate: 10%; at least 2.7-fold (0.44 log units) between middle value and limit.
By their numbers in this assay, from the lowest: compounds 3, 1 and 2 (each within the scatter of the next, the first and the last beyond it). At a limit, above all of these: compound 4.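

Compound 4 gives no number in this assay, only a limit: the limit of > 50000 nM in this assay, at which 1 of the 4 values shown sits. Its floors are an at least 4.2-fold higher number from compound 3 to compound 4 (0.62 log units; beyond the scatter) and an at least 2.8-fold higher number from compound 1 to compound 4 (0.45 log units; beyond the scatter), so this carbonyl carbon, where the earlier groups moved the numbers only modestly at most, can lose far more with piperidin-1-yl in place. Against butylamino the reading is less firm, with an at least 1.9-fold higher number from compound 2 to compound 4 (0.29 log units; that floor lies within the scatter).

From the compounds shown here alone, how far compound 4 lies beyond its limit stays open. So does whether the ring matters, or the missing amide hydrogen, which an open-chain dimethylamino group or a pyrrolidin-1-yl ring at this carbonyl carbon could help separate.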